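Chloro on the phenyl ring: expected cytotoxicity of compound 4

The source may hold more compounds than are shown below. What is called first, only, known or untested is meant among the compounds shown, and "the series" means these compounds.

Three compounds have been measured in an ADME assay on Vero cells (Chlorocebus sabaeus) for cytotoxicity, read by MTT assay, with a stated time of 72 h; a lower number here means a stronger inhibitor, a higher number a weaker inhibitor:

- compound 1, `O=C(Nc1nc(-c2ccccc2)cs1)c1ccc([N+](=O)[O-])o1`, gives 41700 nM
- compound 2, `COc1ccc(-c2csc(NC(=O)c3ccc([N+](=O)[O-])o3)n2)cc1`, gives 63000 nM
- compound 3, `COc1ccccc1-c1csc(NC(=O)c2ccc([N+](=O)[O-])o2)n1`, gives 42000 nM

Compound 1 carries no substituent on its phenyl ring. Its number cannot be told apart from the other two: the step of a 1.5-fold higher number from compound 1 to compound 2 (0.18 log units; within the scatter) and the step of a 1.0-fold higher number from compound 1 to compound 3 (0.00 log units; within the scatter) are both within the scatter, and the comparison between the two methoxy isomers, a 1.5-fold lower number from compound 2 to compound 3 (0.18 log units; within the scatter), is as well.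

Compound 4, `O=C(Nc1nc(-c2cccc(Cl)c2)cs1)c1ccc([N+](=O)[O-])o1`, differs from compound 1 in one place: chloro in place of hydrogen on an aromatic carbon. For the measured compounds named here, no chloro compound has been measured, so the nearest guides are the two methoxy additions on the same ring, which changed nothing beyond the scatter. On that basis a single small substituent on this ring is expected to leave this assay essentially unchanged, with no direction favoured, so the expected step is a 1.0-fold lower number from compound 1 to compound 4 (0.02 log units; within the scatter). Compound 4 is therefore estimated at 40000 nM, within a range of 20000 nM to 80000 nM.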

Compound 4, half-maximal inhibitory concentration: 43700 nM
Estimate against measurement, compound 4: 1.1-fold (0.04 log units) below; measured number inside the range.
By their numbers in this assay, from the lowest: compounds 1, 3, 4 and 2 (each within the scatter of the next).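

For the compounds shown here, a chloro group on the phenyl ring, meta to a large group, is the first substituent here other than methoxy, and in this assay the addition gives a 1.0-fold higher number from compound 1 to compound 4 (0.02 log units; within the scatter) for the phenyl to 3-chlorophenyl change. Exchanging one substituted ring for another tells the same story, with a 1.0-fold higher number from compound 3 to compound 4 (0.02 log units; within the scatter) and a 1.4-fold lower number from compound 2 to compound 4 (0.16 log units; within the scatter) as the two exchanges. Hydrogen, methoxy and chloro on this ring therefore cannot be told apart in these four compounds, and no measured evidence is available to explain this.

Going by these compounds, what an amine, a carboxylic acid or a longer alkyl chain on this ring would do remains open, as does chloro at the ring's other positions. Everything outside the phenyl ring is the same in all four compounds, so its share in these numbers is unknown.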